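Replacing a quinazolinylmethyl arm with a fluorobenzyl group

The source may hold more compounds than are shown below. What is called first, only, known or untested is meant among the compounds shown, and "the series" means these compounds.

Compound 1, `Cc1cc(Nc2cc(-c3ccccc3)[nH]n2)n2nc(SCc3nc4ccccc4[nH]3)nc2n1`: 4840 nM
Compound 2, `Cc1cc(Nc2ccn(Cc3nc(C)c4ccccc4n3)n2)n2nc(SCc3ccc(Br)cc3)nc2n1`: 5450 nM
Compound 3, `Cc1cc(Nc2cc(-c3ccccc3)[nH]n2)n2nc(SCCc3ccccc3)nc2n1`: 4930 nM

All three compounds were measured in a functional assay on PC-9 cells (Homo sapiens) for inhibition, read by MTT assay, with a stated time of 72 h; a lower number here means a stronger inhibitor, a higher number a weaker inhibitor. Compound 2 gives the highest of the three numbers, but its gaps to compound 3 and to compound 1 lie within the scatter, so the three stand together with no order among them. Going by the values given here, the only step between two compounds that differ in a single place, a 1.0-fold higher number from compound 1 to compound 3 (0.01 log units; within the scatter), is itself within the scatter; it alters the group on the saturated chain carbon bound to a sulfur, which is not the part changed here, so it does not bear directly on the present step.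

Compound 4, `Cc1cc(Nc2ccn(Cc3ccc(F)cc3)n2)n2nc(SCc3ccc(Br)cc3)nc2n1`, has not been measured. It differs from compound 2 by 4-fluorophenyl in place of 4-methylquinazolin-2-yl on a saturated chain carbon bound to an aromatic nitrogen. Among the compounds with values here, no measured pair speaks to this change; the one comparable swap of an aromatic arm, on the other side of the core, was flat. The step is therefore expected to stay within the scatter: a 1.0-fold higher number from compound 2 to compound 4 (0.00 log units; within the scatter). In this assay compound 4 is estimated at 5500 nM, with a range from 2500 nM to 12000 nM.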

Compound 4, half-maximal inhibitory concentration: 19400 nM
Compound 4: the middle estimate sits 3.5-fold (0.55 log units) below what was measured; measured number outside the range, above it.
By their numbers in this assay, from the lowest: compounds 1, 3 and 2 (each within the scatter of the next); then compound 4.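

In this assay, going by these compounds alone, the group on the saturated chain carbon bound to an aromatic nitrogen turns out to matter, and it gives the first step beyond the scatter in this set: a 3.6-fold higher number from compound 2 to compound 4 (0.55 log units; beyond the scatter), with 4-fluorophenyl in place of 4-methylquinazolin-2-yl. Here the weaker number goes with the smaller arm, which has one six-membered aromatic ring of carbon only and no hydrogen-bond acceptors, so this arm is not interchangeable in the way the flat step on the other side of the core might have suggested. Nothing at hand explains the size of this step.

Within the data shown here, the single step cannot separate the loss of the quinazoline ring from the arrival of the fluorine. It also leaves open whether an amine, a carboxylic acid or a longer chain on this carbon would bring the number back towards that of compound 2.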